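Serine side chain in place of protected lysine side chain

A few compounds are considered here, and "the series" means these few. Any claim that something is new, unique, unknown or untested is made for them only; others in the source may bear on it.

Measured so far:
compound 1 `N=C(N)NCCC[C@H](NC(=O)CN(c1nc(Cl)nc2c1ncn2C1CCCCO1)C1CC1)C(=O)OCc1ccccc1` gives 61.6% in a functional assay on the whole organism with Mus musculus as the target, with a stated time of 90 min, at a dose of 25 umol/kg by the oral route; on this read-out higher numbers stand for a stronger effect at the one dose given and lower numbers for a weaker effect
compound 2 `CC(C)(C)OC(=O)NCCCC[C@H](NC(=O)CN(c1nc(Cl)nc2c1ncn2C1CCCCO1)C1CC1)C(=O)OCc1ccccc1` gives 32.9% in this assay

Compound 2 stands lowest of the two numbers, with compound 1 above it beyond the scatter. Compound 3 `O=C(CN(c1nc(Cl)nc2c1ncn2C1CCCCO1)C1CC1)N[C@@H](CO)C(=O)OCc1ccccc1` differs from compound 2 in one place: hydroxy in place of 3-((tert-butoxycarbonyl)amino)propyl on a saturated chain carbon, two bonds along the chain from an amide-type nitrogen and a carbonyl carbon. Going by the values given here, the one measured step, a number 28.7 percentage points lower from compound 1 to compound 2 (beyond the scatter), changes a different part of the side chain and does not cover cutting it back to hydroxy; no measured pair bears directly on this change. The step is therefore expected small, a number 5.1 percentage points higher from compound 2 to compound 3 (within the scatter), with a wide range. Compound 3 is expected at 38%, between 12% and 64%.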

Compound 3, a percentage reported as activity, at one dose (the size of the read-out at that dose, not a potency): 32.2%
Beside the measured number, compound 3's estimate is 5.8 percentage points above it, and the stated range covers the measured number.
By their numbers in this assay, from the lowest: compounds 3 and 2 (each within the scatter of the next); then compound 1.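

In this assay, hydroxy in place of 3-((tert-butoxycarbonyl)amino)propyl gives a number 0.7 percentage points lower from compound 2 to compound 3 (within the scatter), so this change on the saturated chain carbon separates the two compounds by no more than the scatter. The side chain of compound 1 remains apart from hydroxy as well, with a number 29.4 percentage points lower from compound 1 to compound 3 (beyond the scatter). Nothing available explains either step.

The compounds shown leave open whether the higher number of compound 1 follows its terminal group or its chain length. A free primary amine or a carboxylic acid on a chain of the same length would bear on this.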